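Nitro in place of chloro: what tolerance to expect

A few compounds are considered here, and "the series" means these few. Any claim that something is new, unique, unknown or untested is made for them only; others in the source may bear on it.

The three measured compounds share one core, seen in compound 1 `O=C(N/N=C/c1ccccc1)c1cccnc1`. In an ADME assay on HeLa cells (Homo sapiens) for cytotoxicity, read by microscopy (a higher number here means that more compound is tolerated, a lower number that less compound is tolerated), compound 1 gives 100 ug/mL. Compound 2 `O=C(N/N=C/c1ccc(Cl)cc1)c1cccnc1` adds a chloro group on an aromatic carbon. In this assay compound 2 reaches only a limit of the assay, > 100 ug/mL. Compound 3 `O=C(N/N=C/c1ccccc1[N+](=O)[O-])c1cccnc1` adds a nitro group on an aromatic carbon instead. In this assay compound 3 also stops at a limit, > 100 ug/mL. Compound 2 therefore stands at the limit of > 100 ug/mL in this assay, at which 2 of the 3 values shown sit, so no number separates it from compound 3, and compound 1 sits just at that same concentration with a real reading.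

Two measured steps exist: a number no lower from compound 1 to compound 2 (the limit leaves the size open) and a number no lower from compound 1 to compound 3 (the limit leaves the size open). Both run toward the limit, so their true size is not readable.

Compound 4 `O=C(N/N=C/c1ccc([N+](=O)[O-])cc1)c1cccnc1` is not yet measured. It differs from compound 2 in one place: nitro in place of chloro on an aromatic carbon. Both measured steps bear on this change, one for the group that leaves and one for the group that enters, and each ended at the limit. The nitro group already sits in compound 3, whose reading of > 100 ug/mL is a limit.

The expected step is a step that the limit leaves unreadable from compound 2 to compound 4, none beyond the scatter. Compound 4 is thus estimated to give 150 ug/mL in this assay, in the range 70 ug/mL to 300 ug/mL.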

Compound 4, minimum cytotoxic concentration: 0.8 ug/mL
For compound 4 the middle estimate is 190-fold (2.27 log units) above the measured one; the measured number lies below the stated range.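

This result shows that a nitro group on an aromatic carbon, para to a large group, can make the compound far less well tolerated in this assay: nitro in place of chloro gives an at least 120-fold lower number from compound 2 to compound 4 (2.09 log units; beyond the scatter), and nitro in place of hydrogen gives a 130-fold lower number from compound 1 to compound 4 (2.10 log units; beyond the scatter). The nitro group alone does not account for the drop among these compounds, since compound 3 also carries a nitro group, at a different aromatic carbon, and compound 3 gives > 100 ug/mL, which is a limit of the assay. So the place of the group matters here as well as its identity, something the earlier readings could not show, as they gave no sharp fall and ended mostly at one ceiling: the limit of > 100 ug/mL in this assay, at which 2 of the 4 values shown sit.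

On these data alone, only hydrogen, chloro and nitro are seen at this place, so it remains open whether the sharp fall belongs to nitro alone or would also appear with an amine, a nitrile or a carboxylic acid there. As far as these compounds go, how much more compound than the limit allows compound 2 would tolerate also stays unknown, so the full size of the step from it remains open.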